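From Thiophen-2-yl to Naphthalen-2-yl on an Amide Carbonyl

The compounds below may be only part of what the source reports. "The series", "measured", "known", "first", "only" and "open" are said of these compounds alone.

Compound 1 `O=C(CSc1cccc(O)c1)Nc1ccc2nc(NC(=O)c3cccs3)sc2c1` gives 7020 nM in a functional assay on HCT-116 cells (Homo sapiens) for antiproliferative activity, read by MTT assay, with a stated time of 72 h; on this read-out lower numbers stand for stronger inhibition and higher numbers for weaker inhibition.
Compound 2 `CC(O)c1cccc(NC(=O)c2cc(Br)ccc2Br)c1` gives only a limit in this assay, > 100000 nM.
Compound 3 `Cc1ccc(S(=O)(=O)Nc2nc(C)c(NC(=O)Nc3ccc(Cl)cc3)s2)cc1` gives 47400 nM in this assay.

All three compounds were tested the same way, in this assay. Of the two compounds with a number, compound 1 has the lower one, and so the stronger inhibition; compound 3 sits at a higher number, and the gap between the two is beyond the usual scatter of repeated measurements. Compound 2 stands apart in that its result is a limit rather than a number: the limit of > 100000 nM in this assay, at which 1 of the 3 values shown sits.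

Compound 4 `O=C(CSc1cccc(O)c1)Nc1ccc2nc(NC(=O)c3ccc4ccccc4c3)sc2c1` has not yet been measured. It differs from compound 1 in one place: naphthalen-2-yl in place of thiophen-2-yl on a carbonyl carbon. Going by the values given here, no pair of measured compounds shows what this change does, so the expectation rests on compound 1 alone. The step of a 1.4-fold lower number from compound 1 to compound 4 (0.15 log units; within the scatter) is expected to stay within the scatter, with no clear direction. Compound 4 is estimated at 5000 nM in this assay, with a range from 1500 nM to 20000 nM.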

Compound 4, half-maximal inhibitory concentration: 4250 nM
For compound 4 the middle estimate is 1.2-fold (0.07 log units) above the measured one, within the range that was stated.
By their numbers in this assay, from the lowest: compounds 4 and 1 (each within the scatter of the next); then compound 3. At a limit, above all of these: compound 2.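

Replacing thiophen-2-yl with naphthalen-2-yl on the carbonyl carbon in this assay gives a 1.7-fold lower number from compound 1 to compound 4 (0.22 log units; within the scatter), so this position tolerates a group of 10 heavy atoms with two six-membered aromatic rings in place of a five-membered aromatic ring of 5 heavy atoms. Going by these compounds alone, this is the first direct reading of a single change here, and the loss of the sulfur and of the ring's hydrogen-bond acceptor leaves no shift that can be told from the scatter. Nothing measured here explains why these two groups read alike.

Within the data shown here, with only two aromatic groups compared at this place, it remains open how a methyl group, a plain phenyl ring or a longer chain ending in an amine would read. As far as these compounds go, the other parts of the molecule stay unchanged in this pair, so what they contribute also remains open.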